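A few compounds are considered here, and "the series" means these few. Any claim that something is new, unique, unknown or untested is made for them only; others in the source may bear on it.

Compound 1 `Nc1nc(Cl)c(-c2ccccn2)c(N[C@@H]2C[C@H](CO)[C@@H](O)[C@H]2O)n1`: in an ADME assay on cells (Homo sapiens) for cytotoxicity, read by polymerase chain reaction, with a stated time of 3 days (on this read-out lower numbers stand for higher toxicity in this test and higher numbers for lower toxicity in this test), compound 1 gives > 25000 nM, a limit of the assay.
Compound 2 `Nc1nc(Cl)c(-c2cccs2)c(N[C@@H]2C[C@H](CO)[C@@H](O)[C@H]2O)n1`: in this assay compound 2 gives > 25000 nM, also a limit.
Compound 3 `Nc1nc(Cl)c(-c2nc3ccccc3s2)c(N[C@@H]2C[C@H](CO)[C@@H](O)[C@H]2O)n1`: in this assay compound 3 gives 14000 nM.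

Compound 3 thus holds the only number shown; the other two values sit at the limit of > 25000 nM in this assay, at which 2 of the 3 values shown sit. The measured steps, an at least 1.7-fold lower number from compound 1 to compound 3 (0.25 log units; that floor lies within the scatter) and an at least 1.7-fold lower number from compound 2 to compound 3 (0.25 log units; that floor lies within the scatter), along with a step that the two limits leave unreadable from compound 1 to compound 2, all change the group on the aromatic carbon of the shared core. Compound 4 `CCOc1ccc2nc(-c3c(Cl)nc(N)nc3N[C@@H]3C[C@H](CO)[C@@H](O)[C@H]3O)sc2c1` differs from compound 3 elsewhere: ethoxy in place of hydrogen on an aromatic carbon. For the measured compounds named here, no measured step touches that place, so the expectation for compound 4 is a step of a 1.2-fold lower number from compound 3 to compound 4 (0.07 log units; within the scatter), within the scatter. The estimate for compound 4 is therefore 12000 nM, with a range from 3500 nM to 30000 nM.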

Compound 4, half-maximal cytotoxic concentration: > 25000 nM
Compound 4: a limit, no number (the forecaster's own chance of this, stated with the estimate: 30%); middle value at least 2.0-fold (0.31 log units) from the limit.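

Ethoxy in place of hydrogen is the first change at this place on the six-membered aromatic ring of carbon only, and in this assay it gives an at least 1.7-fold higher number from compound 3 to compound 4 (0.25 log units; that floor lies within the scatter). Compound 4 gives a limit, not a number, so that floor is all that can be read of the change, and it shows no sign of higher toxicity in this test. Compound 3 stays the only compound with a number: the limit of > 25000 nM in this assay, at which 3 of the 4 values shown sit.

Going by these compounds, what a methoxy group, an amine or a carboxylic acid would do at this same place stays open.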